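The compounds below may be only part of what the source reports. "The series", "measured", "known", "first", "only" and "open" are said of these compounds alone.

Series notes. Among the measured compounds shown here, compound 2 `C=C1C2=C(C(=O)N1OC)[C@H](OC(=O)CSc1nc3ccccc3o1)[C@@](C)(O)[C@H](CCCCC)O2` holds the second highest of the three numbers so far in a functional assay on PC-3 cells (Homo sapiens) for cytotoxicity, read by MTT assay, with a stated time of 72 h (a lower number here means a stronger inhibitor, a higher number a weaker inhibitor), where compound 2 gives 5800 nM. Its nearest neighbour is compound 1 `C=C1C2=C(C(=O)N1OC)[C@H](OC(=O)CSc1nc3ccccc3s1)[C@@](C)(O)[C@H](CCCCC)O2`, which in this assay gives 5000 nM; the step of a 1.2-fold higher number from compound 1 to compound 2 (0.06 log units; within the scatter) stays within the scatter. Furthest off is compound 3 `C=C1C2=C(C(=O)N1OC)[C@@H](F)[C@@](C)(O)[C@H](CCCCC)O2`, which carries fluoro in place of the whole ester side chain; in this assay compound 3 gives 12000 nM, a higher number than compound 2 and beyond the scatter.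

Compound 4 `C=C1C2=C(C(=O)N1OC)[C@H](OC(=O)CCl)[C@@](C)(O)[C@H](CCCCC)O2` is the next step from compound 2: chloro in place of (1,3-benzoxazol-2-yl)sulfanyl on a saturated chain carbon bound to a carbonyl carbon. For the measured compounds named here, no measured step covers this change. Going by the values given here, the only step in hand, a 1.2-fold higher number from compound 1 to compound 2 (0.06 log units; within the scatter), exchanges one ring system for another on the sulfur and shows that the terminus of the ester can be varied without a change beyond the scatter. Compound 3 shows that dropping the ester altogether goes with a higher number, but compound 4 keeps the ester and its carbonyl, shortening only what lies beyond the chain carbon. Expected, therefore, is a step of a 1.2-fold lower number from compound 2 to compound 4 (0.06 log units; within the scatter), nothing beyond the scatter, with wide uncertainty because no measured analogue exists. Compound 4 is estimated at 5000 nM, with a range from 2000 nM to 13000 nM.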

Compound 4, half-maximal inhibitory concentration: 2400 nM
Compound 4: the middle estimate sits 2.1-fold (0.32 log units) above what was measured, within the range that was stated.
By their numbers in this assay, from the lowest: compound 4; then compounds 1 and 2 (each within the scatter of the next); then compound 3.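

In this assay, chloro in place of (1,3-benzoxazol-2-yl)sulfanyl on a saturated chain carbon bound to a carbonyl carbon gives a 2.4-fold lower number from compound 2 to compound 4 (0.38 log units; beyond the scatter), and chloro in place of (1,3-benzothiazol-2-yl)sulfanyl at the same place gives a 2.1-fold lower number from compound 1 to compound 4 (0.32 log units; beyond the scatter), so both ring-bearing esters stand on the same side of compound 4. Among the compounds shown here, the earlier step showed only that one ring system on the sulfur can replace the other without a change beyond the scatter; these two steps show that the whole sulfur-linked ring group can be replaced by a single chlorine atom, with the ester kept, and that the number then falls beyond the scatter. Nothing at hand indicates what underlies this shift.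

Still open, on these data alone, is whether the lower number belongs to chloro itself or simply goes with the loss of the ring-bearing group, a question that bromo, hydroxyl or a plain hydrogen on the same chain carbon would address. Also open, as far as these compounds go, is how a small amine, a carboxylic acid or a longer chain carrying chloro at its end would read at this place.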